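Alkyne terminus: pyridyl to cyclopentyl in compounds 2 and 3

The compounds below may be only part of what the source reports. "The series", "measured", "known", "first", "only" and "open" are said of these compounds alone.

Measured so far:
compound 1 `C[C@@H](NC(=O)c1ccc(C#Cc2ccccc2)cn1)C(C)(C)O` — 43.2%
compound 2 `C[C@@H](NC(=O)c1ccc(C#Cc2cccnc2)cn1)C(C)(C)O` — 25.9%

In an ADME assay on HEK293 cells for agonist activity at metabotropic glutamate receptor 5 (Rattus norvegicus), read by fluorescence and calcium flux (on this read-out higher numbers stand for larger maximal responses and lower numbers for smaller maximal responses), compound 1 gives 43.2% and compound 2 gives 25.9%. Compound 2 stands lowest of the two numbers in this assay; its nearest neighbour is compound 1, separated by a number 17.3 percentage points lower from compound 1 to compound 2 (beyond the scatter), a modest step beyond the scatter.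

Compound 3 `C[C@@H](NC(=O)c1ccc(C#CC2CCCC2)cn1)C(C)(C)O` differs from compound 2 by cyclopentyl in place of pyridin-3-yl on a triple-bonded carbon. Among the measured compounds shown here, the one measured step, a number 17.3 percentage points lower from compound 1 to compound 2 (beyond the scatter), sits at the same place but exchanges one six-membered aromatic ring for another; no measured step exchanges an aromatic ring for a non-aromatic one, so its direction cannot be carried over directly. Taking that step as the only guide to the size of change at this place, a step of comparable magnitude in either direction, or none beyond the scatter, is expected for compound 3 in this assay, estimated as a number 6.1 percentage points higher from compound 2 to compound 3 (within the scatter). Compound 3 is accordingly estimated at 32%, with a range from 12% to 52%.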

Compound 3, largest response reached (reported as efficacy), in percent of the reference or control that the assay uses: 14.8%
The estimate for compound 3 lay 17.2 percentage points above the measured number; the measured number falls inside the stated range.
By their numbers in this assay, from the lowest: compound 3; then compound 2; then compound 1.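

In this assay, among the compounds shown here, the triple-bonded carbon now carries a non-aromatic ring for the first time: cyclopentyl gives a number 11.1 percentage points lower from compound 2 to compound 3 (beyond the scatter) and, against phenyl, a number 28.4 percentage points lower from compound 1 to compound 3 (beyond the scatter) in the same read-out. The earlier pair compared only two six-membered aromatic rings; here both aromatic rings stand above the five-membered non-aromatic ring, with no compound shown going against that order, though it rests on a single cyclopentyl example. Nothing available explains this order.

Cyclopentyl differs from the aromatic rings in both ring size and aromaticity, so the compounds shown cannot separate the two; cyclohexyl would bear directly on that question. From the compounds shown here alone, how an open chain such as tert-butyl, or a phenyl ring carrying an amine, would behave at this place also remains open.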